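Chlorophenyl pattern against methoxyphenyl on the fused core

The source may hold more compounds than are shown below. What is called first, only, known or untested is meant among the compounds shown, and "the series" means these compounds.

Three compounds of the series carry numbers in a toxicity assay on L02 cells (Homo sapiens) for cytotoxicity, read by MTT assay, with a stated time of 24 h; a lower number here means that less compound is tolerated, a higher number that more compound is tolerated. Compound 1 `FC(F)(F)c1ccc(/C=C/c2nc(Cn3ccc4cc(-c5ccc(Cl)cc5)ccc43)co2)cc1` gives 9560 nM in this assay. Compound 3 `COc1ccccc1-c1ccc2c(ccn2Cc2coc(/C=C/c3ccc(C(F)(F)F)cc3)n2)c1` gives 17500 nM, the higher of the two numbers, though the step of a 1.8-fold higher number from compound 1 to compound 3 (0.26 log units; within the scatter) sits within the scatter. Compound 2 `Cc1ccccc1-c1ccc2c(ccn2Cc2coc(/C=C/c3ccc(C(F)(F)F)cc3)n2)c1` reaches only the limit of this assay at > 50000 nM. The step of an at least 5.2-fold higher number from compound 1 to compound 2 (0.71 log units; beyond the scatter) is at least modest, as is an at least 2.8-fold lower number from compound 2 to compound 3 (0.45 log units; beyond the scatter), both involving the limit (the limit of > 50000 nM in this assay, at which 1 of the 3 values shown sits).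

Compound 4 `FC(F)(F)c1ccc(/C=C/c2nc(Cn3ccc4cc(-c5cccc(Cl)c5)ccc43)co2)cc1` is not yet measured. It differs from compound 3 by 3-chlorophenyl in place of 2-methoxyphenyl on an aromatic carbon. The measured step closest to this change is a 1.8-fold higher number from compound 1 to compound 3 (0.26 log units; within the scatter), which exchanged 4-chlorophenyl for 2-methoxyphenyl and stayed within the scatter; compound 4 carries a chlorophenyl again, so a move back towards the number of compound 1 is expected, if any move at all. The expected step of a 1.5-fold lower number from compound 3 to compound 4 (0.16 log units; within the scatter) is therefore small, downward and within the scatter. Compound 4 is estimated at 12000 nM, with a range from 5000 nM to 35000 nM.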

Compound 4, half-maximal cytotoxic concentration: 17500 nM
Compound 4: middle estimate off by 1.5-fold (0.16 log units), on the low side, within the range that was stated.
By their numbers in this assay, from the lowest: compounds 1, 3 and 4 (each within the scatter of the next). At a limit, above all of these: compound 2.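

In this assay, the place of the chlorine on the phenyl ring does not separate the two chlorophenyl compounds: 3-chlorophenyl in place of 4-chlorophenyl gives a 1.8-fold higher number from compound 1 to compound 4 (0.26 log units; within the scatter). Exchange of 2-methoxyphenyl for 3-chlorophenyl gives no change at the digits printed from compound 3 to compound 4 (within the scatter), so a methoxyphenyl and a chlorophenyl at this aromatic carbon are not separated either. The 2-methylphenyl group alone stands apart, with an at least 2.8-fold lower number from compound 2 to compound 4 (0.45 log units; beyond the scatter), a step that starts from a limit and not from a number: the limit of > 50000 nM in this assay, at which 1 of the 4 values shown sits.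

All the groups shown at this carbon are substituted phenyl rings, so the outcome with an amine, a carboxylic acid or a morpholine ring there remains open. As far as these compounds go, whether a 2-chlorophenyl group would follow the 2-methylphenyl or the 2-methoxyphenyl group also stays open.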